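Two Benzoxazole Sulfonamides and a Methyl-for-Fluorine Swap

The compounds below may be only part of what the source reports. "The series", "measured", "known", "first", "only" and "open" are said of these compounds alone.

Compound 1, `O=S(=O)(Nc1ccc2oc(-c3ccccc3)nc2c1)c1ccc(Cl)cc1`, gives 65000 nM in an ADME assay on HEK293 cells (Homo sapiens) for cytotoxicity, read by resazurin assay, with a stated time of 48 h; a lower number here means that less compound is tolerated, a higher number that more compound is tolerated.
Compound 2, `O=S(=O)(Nc1ccc(-c2nc3ccccc3o2)cc1)c1ccccc1F`, gives > 100000 nM in this assay.

The result for compound 2 is a limit of the assay, not a number, marked by the limit of > 100000 nM in this assay, at which 1 of the 2 values shown sits. Compound 3, `Cc1cccc(S(=O)(=O)Nc2ccc(-c3nc4ccccc4o3)cc2)c1`, is not yet measured; it differs from compound 2 by 3-methylphenyl in place of 2-fluorophenyl on a sulfonyl sulfur. Among the measured compounds shown here, no step between measured compounds is available to guide the size of this change, so the expected step of a number no higher from compound 2 to compound 3 (the limit leaves the size open) is none beyond the usual scatter. Compound 3 is therefore estimated at 100000 nM, with a range from 40000 nM to 250000 nM.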

Compound 3, half-maximal cytotoxic concentration: > 100000 nM
Compound 3 gave a limit, no number (the forecaster's own chance of this, stated with the estimate: 60%); the middle value lies on the limit itself.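

Compound 2 and compound 3 both give a limit of the assay rather than a number, so no step can be read between them: the limit of > 100000 nM in this assay, at which 2 of the 3 values shown sit.

On these data alone, whether 3-methylphenyl in place of 2-fluorophenyl on a sulfonyl sulfur changes the result in this assay stays open.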